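Cytotoxicity notes on the shared core: the fluoro step

The compounds below may be only part of what the source reports. "The series", "measured", "known", "first", "only" and "open" are said of these compounds alone.

Compound 1, `CC(C)OCCCNC(=O)c1csc(Nc2cc(Cl)c(Cl)c(Cl)c2)n1`, in an ADME assay on MDCK cells (Canis lupus familiaris) for cytotoxicity, with a stated time of 48 h (on this read-out lower numbers stand for higher toxicity in this test and higher numbers for lower toxicity in this test), gives > 100000 nM, a limit of the assay rather than a number.
Compound 2, `CC(C)OCCCNC(=O)c1csc(Nc2ccc(Cl)cc2)n1`, gives > 100000 nM, again a limit.
Compound 3, `CCOCCCNC(=O)c1csc(Nc2ccc(Cl)cc2)n1`, gives > 100000 nM, also a limit.

Compound 3 therefore stands at the assay limit, together with the two others (the limit of > 100000 nM in this assay, at which 3 of the 3 values shown sit). For the measured compounds named here, the only single-place step among the measured compounds, a step that the two limits leave unreadable from compound 2 to compound 3, cannot be read from two limits. Compound 4, `CCOCCCNC(=O)c1csc(Nc2ccc(Cl)c(F)c2)n1`, differs from compound 3 by fluoro in place of hydrogen on an aromatic carbon. Going by the values given here, no measured step bears on such a ring change, and the one recorded step is unreadable, so nothing beyond the scatter is expected in this assay from compound 3 to compound 4. Compound 4 is expected to give only a limit again, estimated at 150000 nM with a range from 50000 nM to 500000 nM. The step this estimate means is a step that the limit leaves unreadable from compound 3 to compound 4.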

Compound 4, half-maximal cytotoxic concentration: > 100000 nM
Compound 4 gave a limit, no number; the forecaster's own chance of this, stated with the estimate: 80%; the middle value lies beyond the limit too.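

No new step can be read from compound 3 to compound 4, as both values are limits of the assay: the limit of > 100000 nM in this assay, at which 4 of the 4 values shown sit.

The compounds shown leave open whether any change on the shared core gives a readable number in this assay.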